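The source may hold more compounds than are shown below. What is called first, only, known or untested is meant among the compounds shown, and "the series" means these compounds.

Two compounds share one core and differ only in the ring attached to the sulfonyl sulfur. Compound 1 `CNCc1cn(S(=O)(=O)c2cccs2)c(-c2cccnc2F)c1F` carries thiophen-2-yl there, and in a functional assay on the whole organism (strain Jcl:Sprague-Dawley) for inhibition, with Rattus norvegicus as the target, with stated times of 3 min and 3 h, at a dose of 1 mg/kg by the intravenous route (a lower number here means less inhibition, a higher number more inhibition at the dose given (going by the name of the read-out)), compound 1 gives 98%. Compound 2 `CNCc1cn(S(=O)(=O)c2ccco2)c(-c2cccnc2F)c1F` carries furan-2-yl instead, and in this assay compound 2 gives 75%. For the measured compounds named here, the one measured step, a number 23 percentage points lower from compound 1 to compound 2 (beyond the scatter), leaves compound 2 as the lower of the two numbers.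

Compound 3 `CNCc1cn(S(=O)(=O)c2ccoc2)c(-c2cccnc2F)c1F` keeps everything of compound 2 except the furan ring, which is exchanged as follows: furan-3-yl in place of furan-2-yl on a sulfonyl sulfur. Going by the values given here, no measured step covers this exchange; the thiophene-to-furan step concerns a different change and gives no guide to swapping furan-2-yl for furan-3-yl. Without a bearing step, the expected step of a number 5 percentage points lower from compound 2 to compound 3 (within the scatter) is one that stays within the scatter, although a modest change in either direction cannot be ruled out. Compound 3 is therefore estimated at 70% in this assay, with a range from 45% to 92%.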

Compound 3, a percentage reported as inhibition, in the whole organism at one dose (the size of the read-out at that dose, not a potency): 95%
Beside the measured number, compound 3's estimate is 25 percentage points below it; measured number above the stated range.
By their numbers in this assay, from the lowest: compound 2; then compounds 3 and 1 (each within the scatter of the next).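

Changing only where the furan ring joins the sulfonyl sulfur, with the same atoms joined differently, has a clear effect in this assay: furan-3-yl in place of furan-2-yl gives a number 20 percentage points higher from compound 2 to compound 3 (beyond the scatter) and this step lies beyond the usual scatter. The lower number seen earlier with furan-2-yl therefore does not apply to furan rings as a whole, since furan-3-yl in place of thiophen-2-yl gives a number 3 percentage points lower from compound 1 to compound 3 (within the scatter) and this step stays within the scatter. Among these three compounds, then, the read-out at this position depends on how the ring is attached and not just on which five-membered aromatic ring is present.

Nothing available here explains why the two furan attachments give different numbers. Still open, from the compounds shown here alone, is how thiophen-3-yl, a phenyl ring or a simple methyl group on the sulfonyl sulfur would compare, and whether the gap between the two furan compounds would persist at lower doses, where a number close to the top of the percentage scale has more room to fall.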